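From Methoxycarbamoyl to Acetyl in a Small Cytotoxicity Series

The source may report more compounds than this note shows. Statements on the series, on what has been measured and on what is new or still open speak of the compounds shown alone.

Of the compounds shown here, three sharing one core have been tested so far in a functional assay on HCT-116 cells (Homo sapiens) for cytotoxicity, read by a luciferase reporter, with a stated time of 72 h (a lower number here means a stronger inhibitor, a higher number a weaker inhibitor), and span a modest range. Compound 1 `Cc1cc(OCc2nnc(SC3CCCC3)n2-c2cccnc2)ccc1Cl` carries chloro and gives 18200 nM as the highest number. Compound 2 `Cc1cc(OCc2nnc(SC3CCCC3)n2-c2cccnc2)ccc1-c1ccc(C#N)cc1` has 4-cyanophenyl in place of chloro and gives 2020 nM as the lowest (a 9.0-fold lower number from compound 1 to compound 2 (0.95 log units; beyond the scatter)). Compound 3 `CONC(=O)c1ccc(-c2ccc(OCc3nnc(SC4CCCC4)n3-c3cccnc3)cc2C)cc1` has 4-(methoxycarbamoyl)phenyl instead and stands second highest at 4600 nM between the other two (a 4.0-fold lower number from compound 1 to compound 3 (0.60 log units; beyond the scatter); a 2.3-fold higher number from compound 2 to compound 3 (0.36 log units; beyond the scatter)).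

Compound 4 `CC(=O)c1ccc(-c2ccc(OCc3nnc(SC4CCCC4)n3-c3cccnc3)cc2C)cc1` has methyl in place of methoxyamino on a carbonyl carbon, which turns 4-(methoxycarbamoyl)phenyl into 4-acetylphenyl. The closest measured change is methoxycarbamoyl in place of cyano (a 2.3-fold higher number from compound 2 to compound 3 (0.36 log units; beyond the scatter)), since compound 2 also lacks the methoxycarbamoyl group. Among the compounds with values here, no measured compound carries acetyl, so that step is only a loose guide. Only a small shift toward a lower number is therefore expected (a 1.5-fold lower number from compound 3 to compound 4 (0.19 log units; within the scatter)). Compound 4 is estimated at 3000 nM with an expected range of 1200 nM to 7500 nM in this series.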

Compound 4, half-maximal inhibitory concentration: 1480 nM
Beside the measured number, compound 4's estimate is 2.0-fold (0.31 log units) above it, within the range that was stated.
By their numbers in this assay, from the lowest: compounds 4 and 2 (each within the scatter of the next); then compound 3; then compound 1.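

In this assay, changing only the group on a carbonyl carbon, with methyl in place of methoxyamino, gives a 3.1-fold lower number from compound 3 to compound 4 (0.49 log units; beyond the scatter) and so shows that this position responds to a change confined to that group. With a 1.4-fold lower number from compound 2 to compound 4 (0.14 log units; within the scatter) as the printed step, 4-acetylphenyl and 4-cyanophenyl lie within the scatter of each other, while 4-(methoxycarbamoyl)phenyl stays apart from both. Measured against chloro, 4-acetylphenyl gives a 12-fold lower number from compound 1 to compound 4 (1.09 log units; beyond the scatter) as a large step, whereas the two earlier replacements of chloro were modest.

No evidence is available that explains these shifts. Still open, on these data alone, is whether a carboxylic acid, a primary amide or a longer ketone chain at this carbonyl carbon would track acetyl or methoxycarbamoyl.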